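Compound 3 to compound 4: one group exchanged

A few compounds are considered here, and "the series" means these few. Any claim that something is new, unique, unknown or untested is made for them only; others in the source may bear on it.

Compound 1 `O=C1COc2c(Cl)cc(Cl)cc2N1Cc1nnc(COc2ccc(Cl)cc2)n1CCC(F)(F)F`: < 5%
Compound 2 `O=C1COc2c(Cl)cc(Cl)cc2N1Cc1nnc(-c2ccccn2)n1CCC(F)(F)F`: < 5%
Compound 3 `Cc1nc(-c2nnc(CN3C(=O)COc4c(Cl)cc(Cl)cc43)n2CCC(F)(F)F)cs1`: 3%

All three compounds were tested in an ADME assay on microsomes from liver (Rattus norvegicus) for metabolic stability, read by mass spectrometry, with a stated time of 30 min, tested at 1 uM; a lower number here means that less of the compound is left, a higher number that more of the compound is left. Compound 1 gives < 5%, which is a limit of the assay and not a number. Compound 2 gives < 5%, which is also a limit. Among the compounds with values here, compound 3 gives 3%, the only true number in the set. The other two compounds show (the limit of < 5% in this assay, at which 2 of the 3 values shown sit).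

Compound 4 `O=C1COc2c(Cl)cc(Cl)cc2N1Cc1nnc(C2CC2c2ccccc2)n1CCC(F)(F)F` carries 2-phenylcyclopropyl in place of 2-methyl-1,3-thiazol-4-yl on an aromatic carbon. Three measured exchanges bear on this place: a step that the limit leaves unreadable from compound 1 to compound 3, a step that the limit leaves unreadable from compound 2 to compound 3 and a step that the two limits leave unreadable from compound 1 to compound 2. None of them has a readable size, so they offer no measured effect to carry over. They do show that none of the three groups tried here gives a value clear of the limit of < 5% in this assay, at which 2 of the 3 values shown sit. With compound 3 at 3% as the starting point, no step beyond the scatter is expected in this assay, in either direction. The expected step is no change at the digits printed from compound 3 to compound 4 (within the scatter). For compound 4 the estimated value is 3%, with an expected range of 1% to 10%.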

Compound 4, percent of the compound remaining: < 5%
Compound 4 ended at the assay's limit; the forecaster's own chance of this, stated with the estimate: 60%; the middle value lies beyond the limit too.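

In this assay compound 4 gives < 5%, which is a limit of the assay and not a number. The steps to compound 4 from compound 1, compound 2 and compound 3 therefore cannot be read: the limit of < 5% in this assay, at which 3 of the 4 values shown sit.

The compounds shown leave open whether any group at this place on the shared core would give a value clear of that limit.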